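A Methyl on the Amine Nitrogen, Tested Across Two Cores

The source may hold more compounds than are shown below. What is called first, only, known or untested is meant among the compounds shown, and "the series" means these compounds.

The measured compounds are:
Compound 1, `COc1ccc(C(=O)c2ccc(OC)c3c2OC(C)(C)C=C3)c(NC(=O)CN)c1`, which in a functional assay on A549 cells (Homo sapiens) for antiproliferative activity, read by MTT assay, with a stated time of 48 h (on this read-out lower numbers stand for stronger inhibition and higher numbers for weaker inhibition), gives 270 nM.
Compound 2, `CNCC(=O)Nc1cc(OC)ccc1C(=O)c1ccc(OC)c2c1OC(C)(C)C=C2`, which in this assay gives 620 nM.
Compound 3, `C=C(c1ccc2c(c1)C=CC(C)(C)O2)c1ccc(OC)cc1NC(=O)CN`, which in this assay gives 60 nM.

Compounds 1 and 2 share one core and differ in a single place: methyl in place of hydrogen on an amine nitrogen. This change produced a 2.3-fold higher number from compound 1 to compound 2 (0.36 log units; beyond the scatter), so the methyl on the amine nitrogen weakened inhibition on that core. Compound 3 carries a different core; the difference between the two cores is not broken down here. Compound 3 gives the lowest number of the three, and its steps to compound 1 and to compound 2 both lie beyond the usual scatter.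

Compound 4, `C=C(c1ccc2c(c1)C=CC(C)(C)O2)c1ccc(OC)cc1NC(=O)CNC`, is not yet measured. It stands to compound 3 as compound 2 stands to compound 1: the change is methyl in place of hydrogen on an amine nitrogen, the same kind of change, made at a place described in the same words. Among the measured compounds shown here, the only precedent for this change in the set is the pair of compounds 1 and 2, and on that pair alone the expectation for compound 4 rests. The step from compound 3 to compound 4 in this assay is expected to resemble the earlier one, roughly a 2.3-fold higher number from compound 3 to compound 4 (0.37 log units; beyond the scatter), because a 2.3-fold higher number from compound 1 to compound 2 (0.36 log units; beyond the scatter) was modest but beyond the scatter. Compound 4 is therefore estimated at 140 nM, with a plausible range from 70 nM to 300 nM.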

Compound 4, half-maximal inhibitory concentration: 200 nM
The estimate for compound 4 lay 1.4-fold (0.15 log units) below the measured number; the range from low to high includes it.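

Measured in this assay, methyl in place of hydrogen on the amine nitrogen gave a 3.3-fold higher number from compound 3 to compound 4 (0.52 log units; beyond the scatter) and so weakened inhibition on the core of compound 3, as the same change had on the core of compound 1. The two steps therefore agree in direction, and their sizes cannot be told apart: the same change on two cores in this assay, a 2.3-fold higher number (0.36 log units; beyond the scatter) from compound 1 to compound 2 and a 3.3-fold higher number (0.52 log units; beyond the scatter) from compound 3 to compound 4, 1.5-fold (0.16 log units) apart, within the scatter of two such steps

Among the compounds shown here, this agreement supports carrying the change from one core to the other, but it rests on only two pairs in a single assay. It does not show that the step would hold on any further core, and it offers no explanation of why the methyl weakens inhibition on either core.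

Still open, from the compounds shown here alone, is whether the trend would continue with a larger group on the same nitrogen, such as ethyl, or with a second methyl that would give a dimethylamino group. Also open, going by these compounds, is how either core would respond to a hydroxyl group in place of the amino group, or to a longer chain in place of the aminomethyl group.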